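Swapping methyl for fluoro on a low-ranked compound

The source may report more compounds than this note shows. Statements on the series, on what has been measured and on what is new or still open speak of the compounds shown alone.

Compound 1 `Cc1[nH]c2ccccc2c(=O)c1C1CCCCC1` gives 230 10^-6 cm/s
Compound 2 `Cc1ccc2[nH]c(C)c(Br)c(=O)c2c1` gives 42.2 10^-6 cm/s

Both numbers come from an ADME assay for permeability, using PAMPA, at pH 7.4 (a lower number here means that the compound crosses the layer more slowly, a higher number that the compound crosses the layer faster), and are the only two available so far. Compound 2 has the lower of them, and compound 1 lies above it by more than the usual scatter. These two compounds differ in more than one place, so their gap offers no direct guide to a swap at one spot.

Compound 3 `Cc1[nH]c2ccc(F)cc2c(=O)c1Br` has not yet been measured. It departs from compound 2 by one exchange, fluoro in place of methyl on an aromatic carbon.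

Among the compounds with values here, no measured pair shows this exchange, so compound 2 at 42.2 10^-6 cm/s serves as the anchor. Only a small downward step is expected in this assay, one that stays within the scatter. The estimated step is a 1.3-fold lower number from compound 2 to compound 3 (0.12 log units; within the scatter) (an expectation, not a measurement). Compound 3 is estimated at 32 10^-6 cm/s (expected range 13 10^-6 cm/s to 75 10^-6 cm/s).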

Compound 3, apparent permeability: 18.3 10^-6 cm/s
For compound 3 the middle estimate is 1.7-fold (0.24 log units) above the measured one; low and high end bracket the measured number.
By their numbers in this assay, from the lowest: compound 3; then compound 2; then compound 1.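

In this assay, within the data shown here, fluoro in place of methyl on an aromatic carbon gives a 2.3-fold lower number from compound 2 to compound 3 (0.36 log units; beyond the scatter), the first comparison in this set that isolates a change at one spot. This step is modest, yet it shows that the position, meta to a fused ring and para to a fused ring, affects the read-out, even though the swap exchanges only one heavy atom and the counts show no hydrogen-bond donor, hydrogen-bond acceptor or net charge on either group. No measurement offered here gives a reason for this step.

Among these compounds, only this one exchange can be read at the position, so it remains open where a chloro or methoxy group would fall there. As far as these compounds go, it is also open whether fluoro in place of methyl would give a similar step on the core of compound 1.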